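Solubility notes on the shared core: compound 4

The source may report more compounds than this note shows. Statements on the series, on what has been measured and on what is new or still open speak of the compounds shown alone.

Among the measured compounds shown here, compound 3 `CCOC(=O)C1=C(C)N/C(=C/c2cc(C)n(-c3ccc(OC)cc3)c2C)C1=O` gives 3.1 ug/mL in a physicochemical assay for solubility, read by nephelometry, in phosphate buffer, measured as kinetic solubility, at pH 6.5 (a lower number here means a less soluble compound, a higher number a more soluble compound), the highest of the three numbers measured so far, although its steps to the other two compounds both lie within the scatter. Compound 1 `CCOC(=O)C1=C(C)N/C(=C/c2cc(C)n(-c3ccc(Cl)cc3)c2C)C1=O` gives 1.6 ug/mL in this assay, and compound 2 `CCOC(=O)C1=C(C)N/C(=C/c2cc(C)n(-c3ccc(Br)cc3)c2C)C1=O` gives 2.1 ug/mL. For the measured compounds named here, the three measured steps, a 1.3-fold higher number from compound 1 to compound 2 (0.12 log units; within the scatter), a 1.9-fold higher number from compound 1 to compound 3 (0.29 log units; within the scatter) and a 1.5-fold higher number from compound 2 to compound 3 (0.17 log units; within the scatter), all stay within the scatter, so the series to date shows a narrow band of low solubility with no step that separates one compound from another.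

Compound 4 `CCOC(=O)C1=C(C)N/C(=C/c2cc(C)n(-c3ccncc3)c2C)C1=O` differs from compound 3 by pyridin-4-yl in place of 4-methoxyphenyl on an aromatic nitrogen. Going by the values given here, none of the measured steps bears directly on this change: each of them swaps one substituent on the six-membered aromatic ring for another, while here the ring itself is replaced. The measured steps therefore give no direction, only the observation that changes at this part of the core have so far moved the number little. A modest rise is expected for compound 4, with wide uncertainty, as a 1.9-fold higher number from compound 3 to compound 4 (0.29 log units; within the scatter). The estimate for compound 4 in this assay is 6 ug/mL, with a range from 2 ug/mL to 20 ug/mL.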

Compound 4, solubility: 50 ug/mL
Beside the measured number, compound 4's estimate is 8.3-fold (0.92 log units) below it; the whole stated range lies below it.
By their numbers in this assay, from the lowest: compounds 1, 2 and 3 (each within the scatter of the next); then compound 4.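

In this assay, the exchange of the whole ring on the aromatic nitrogen gives a 16-fold higher number from compound 3 to compound 4 (1.21 log units; beyond the scatter), and the same exchange gives a 24-fold higher number from compound 2 to compound 4 (1.38 log units; beyond the scatter) and a 31-fold higher number from compound 1 to compound 4 (1.49 log units; beyond the scatter). The earlier steps shown here all changed only the substituent on a ring of carbon only and stayed within the scatter, so they left open whether the number could leave that narrow band through a change at this position; these three steps show that it can, and that the identity of the ring counts for far more here than the chloro, bromo or methoxy choice. Nothing at hand explains the size of the step, which stands as an observation on the number alone.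

The change from the three substituted phenyl rings to pyridin-4-yl both puts a nitrogen into the ring and removes the substituent, and the compounds shown do not separate these two parts, which a plain phenyl ring on the same nitrogen would do. Also open, going by these compounds, is how the number would respond to a pyrimidine ring or to a dimethylamino group on the phenyl ring, and whether any such change at this position would match the step seen with pyridin-4-yl.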